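Varying the arylamine on a shared nitrile-bearing core

The source may hold more compounds than are shown below. What is called first, only, known or untested is meant among the compounds shown, and "the series" means these compounds.

Measured so far:
compound 1, `COc1ccc(Nc2nc(SCc3cn(CC(=O)NC(=O)Nc4ccccn4)nn3)nc(-c3ccc(C(C)C)cc3)c2C#N)cc1`: 360 nM
compound 2, `Cc1cccc(Nc2nc(SCc3cn(CC(=O)NC(=O)Nc4ccccn4)nn3)nc(-c3ccc(C(C)C)cc3)c2C#N)c1`: 1650 nM

In a functional assay on B16-F10 cells (Mus musculus) for inhibition, read by MTT assay, with a stated time of 72 h (on this read-out lower numbers stand for stronger inhibition and higher numbers for weaker inhibition), compound 1 gives 360 nM and compound 2 gives 1650 nM. Among the measured compounds shown here, compound 2 thus holds the highest number of the two, and the only measured step, a 4.6-fold higher number from compound 1 to compound 2 (0.66 log units; beyond the scatter), places it a modest distance from compound 1, beyond the scatter.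

Compound 3, `CC(C)c1ccc(Nc2nc(SCc3cn(CC(=O)NC(=O)Nc4ccccn4)nn3)nc(-c3ccc(C(C)C)cc3)c2C#N)cc1`, has not yet been measured. It differs from compound 2 in one place: 4-isopropylphenyl in place of 3-methylphenyl on a nitrogen on an aromatic ring. For the measured compounds named here, no measured step covers this exchange directly. Going by the values given here, the one step that bears on it at all, a 4.6-fold higher number from compound 1 to compound 2 (0.66 log units; beyond the scatter), shows that the aryl group on this nitrogen moves the read-out by a modest amount, so the change to compound 3 is expected to be of similar size or smaller, with the direction uncertain. On balance compound 3 is estimated to come in somewhat lower than compound 2, a step of a 1.8-fold lower number from compound 2 to compound 3 (0.26 log units; within the scatter) in this assay, giving an expected value of 900 nM with a range from 300 nM to 2700 nM.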

Compound 3, half-maximal inhibitory concentration: 4380 nM
Compound 3: the middle estimate sits 4.9-fold (0.69 log units) below what was measured; the measured number lies above the stated range.
By their numbers in this assay, from the lowest: compound 1; then compound 2; then compound 3.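

In this assay, the step of a 2.7-fold higher number from compound 2 to compound 3 (0.42 log units; beyond the scatter) shows that exchanging 3-methylphenyl for 4-isopropylphenyl on this nitrogen raises the number rather than lowering it. The sharper reading comes from a 12-fold higher number from compound 1 to compound 3 (1.09 log units; beyond the scatter), where isopropyl stands in place of methoxy on an aromatic carbon: this single exchange moves the read-out by a large step, so the aryl group on this nitrogen can shift the number further than the first pair showed. No measured information is available to explain why these exchanges move the number as they do.

The compounds shown leave open how much of the step between 3-methylphenyl and 4-isopropylphenyl belongs to the identity of the alkyl group and how much to its place on the ring, since the two differ in both at once. They also leave open whether the lowest number here, held by compound 1, is particular to methoxy, or whether a hydroxyl, an amine or an unsubstituted phenyl on this nitrogen would read in the same way.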